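The compounds below may be only part of what the source reports. "The series", "measured", "known", "first", "only" and "open" are said of these compounds alone.

Compound 1: `O=C(NC(=S)Nc1ccc(Cl)c(-c2nc3ccccc3[nH]2)c1)c1ccc(OCc2ccc(C(F)(F)F)cc2)cc1`, 63900 nM
Compound 2: `Cc1ccc(NC(=O)NC(=O)c2ccc(OCc3ccccc3)cc2)cc1-c1nc2ccccc2[nH]1`, 30100 nM

Both compounds were tested in a functional assay on SW-620 cells (Homo sapiens) for inhibition, read by MTT assay, with a stated time of 48 h; a lower number here means a stronger inhibitor, a higher number a weaker inhibitor. Compound 1 gives 63900 nM, while compound 2 gives 30100 nM. Of the two numbers, compound 2 has the lower one, and its gap to compound 1 is beyond the usual scatter of repeated measurements, so compound 2 is the stronger inhibitor of the pair. The two compounds differ in several places at once, so nothing can be tied to any single part of the structure.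

Compound 3, `Cc1ccc(NC(=O)NC(=O)c2ccc(OCc3ccc(F)cc3)cc2)cc1-c1nc2ccccc2[nH]1`, has not yet been measured. It is built from compound 2 by one change: fluoro in place of hydrogen on an aromatic carbon. The fluorine sits on an aromatic carbon of a six-membered aromatic ring of carbon only, para to a large group. Among the measured compounds shown here, no pair of measured compounds shows what such a single change does here, so there is no step to lean on. A change this small is expected to move the number little, if at all beyond the scatter, and a step of a 1.2-fold lower number from compound 2 to compound 3 (0.08 log units; within the scatter) is expected. Compound 3 is therefore expected to give about 25000 nM in this assay, with a likely range from 10000 nM to 65000 nM.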

Compound 3, half-maximal inhibitory concentration: 35100 nM
The estimate for compound 3 lay 1.4-fold (0.15 log units) below the measured number; the measured number falls inside the stated range.
By their numbers in this assay, from the lowest: compounds 2, 3 and 1 (each within the scatter of the next, the first and the last beyond it).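

Going from benzyloxy to (4-fluorobenzyl)oxy is the first single change that can be read in this assay on its own, and it amounts to a 1.2-fold higher number from compound 2 to compound 3 (0.07 log units; within the scatter) and leaves the two compounds impossible to tell apart in this test. So at this place, on an aromatic carbon of a six-membered aromatic ring of carbon only and para to a large group, swapping hydrogen for fluoro gives no difference that stands clear of the scatter, a point no earlier pair of compounds could show. No further measurement is available that would help explain this result.

From the compounds shown here alone, whether a different group at the same place, such as a methoxy group, an amine or a carboxylic acid, would move the number beyond the scatter remains open, as one small atom says little about larger groups. Going by these compounds, compound 1 does carry a trifluoromethyl group on this ring, but it differs from compound 2 in several places at once, so what that group does on its own also remains unknown.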